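Changing the aryl group on the shared core against trypsin

The compounds below may be only part of what the source reports. "The series", "measured", "known", "first", "only" and "open" are said of these compounds alone.

Compound 1 `Cc1cc(C(=O)Nc2ccc(-c3ccccc3S(N)(=O)=O)cc2)n(-c2cccc(Cl)c2)n1` — in an assay on isolated protein for inhibition of Trypsin (Homo sapiens) (on this read-out higher numbers stand for weaker inhibition and lower numbers for stronger inhibition), compound 1 gives > 1600 nM, which is a limit of the assay and not a number.
Compound 2 `Cc1cc(C(=O)Nc2ccc(-c3ccccc3S(N)(=O)=O)cc2)n(-c2cccc(C(=N)NO)c2)n1` — in this assay compound 2 gives > 1600 nM, again only a limit.

Compound 2 therefore stands at the edge of what this assay reports, together with the other measured compound (the limit of > 1600 nM in this assay, at which 2 of the 2 values shown sit). For the measured compounds named here, the one measured step, a step that the two limits leave unreadable from compound 1 to compound 2, cannot be read because both of its ends are limits. Compound 3 `Cc1cc(C(=O)Nc2ccc(-c3ccccc3S(N)(=O)=O)cc2)n(-c2ccc3ccncc3c2)n1` differs from compound 2 by a group of 10 heavy atoms (9 carbon, 1 nitrogen; one six-membered aromatic ring of carbon only, one six-membered aromatic ring with 1 hetero atom) in place of a group of 10 heavy atoms (7 carbon, 2 nitrogen, 1 oxygen; one six-membered aromatic ring of carbon only), on an aromatic nitrogen. Going by the values given here, no measured step shows how such an exchange shifts the read-out in this assay, so there is nothing to point toward a step beyond the scatter in either direction. Compound 3 is expected to sit near the same limit, so that the step that the limit leaves unreadable from compound 2 to compound 3 is estimated to be small. The estimate for compound 3 is 2500 nM, within a range from 800 nM to 8000 nM.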

Compound 3, inhibition constant in the Trypsin assay: > 1600 nM
Compound 3 ended at the assay's limit; the forecaster's own chance of this, stated with the estimate: 65%; the middle value is on the limit's open side.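

In the Trypsin assay compound 3 gives > 1600 nM, which is a limit of the assay and not a number. For the compounds shown here, the results for compound 1 and compound 2 are limits and not numbers as well, so no step between these compounds can be read: the limit of > 1600 nM in the Trypsin assay, at which 3 of the 3 values shown sit. In a physicochemical assay for acid dissociation, compound 2 gives 7 and compound 3 gives 5.4. The compounds shown leave open whether any aryl group on the shared core can give an actual number in the Trypsin assay.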